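Cyclohexylamide to cyclopentylamide in the hepatic cytotoxicity series

The compounds below may be only part of what the source reports. "The series", "measured", "known", "first", "only" and "open" are said of these compounds alone.

Measured compounds:
compound 1 `O=C(CCn1cnc2cc(-c3noc(CCC4CCCC4)n3)ccc21)N1CCCCC1` — > 20000 nM
compound 2 `O=C(CCn1cnc2cc(-c3noc(CCC4CCCC4)n3)ccc21)NC1CCCCC1` — > 20000 nM

In a toxicity assay on HepG2 2.2.15 cells (Homo sapiens) for cytotoxicity, read by CCK-8 assay, with a stated time of 72 h (a higher number here means that more compound is tolerated, a lower number that less compound is tolerated), compound 1 gives > 20000 nM, which is a limit of the assay and not a number. In this assay compound 2 gives > 20000 nM, again a limit. The step that the two limits leave unreadable from compound 1 to compound 2 therefore cannot be sized. Compound 2 stands where both measured values stand, at the limit of > 20000 nM in this assay, at which 2 of the 2 values shown sit.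

Compound 3 `O=C(CCn1cnc2cc(-c3noc(CCC4CCCC4)n3)ccc21)NC1CCCC1` differs from compound 2 by cyclopentyl in place of cyclohexyl on an amide-type nitrogen. Among the compounds with values here, the only measured step, a step that the two limits leave unreadable from compound 1 to compound 2, touches the same amide-type nitrogen but is unreadable between two limits, so it gives no direction for this assay. With both neighbours of compound 3 in the series sitting at the limit, no shift beyond the scatter is expected from a step that the limit leaves unreadable from compound 2 to compound 3. Compound 3 is estimated at 30000 nM in this assay, with a range from 15000 nM to 80000 nM, and most likely it will again be reported only as a limit.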

Compound 3, half-maximal cytotoxic concentration: > 20000 nM
Compound 3: a limit, no number (the forecaster's own chance of this, stated with the estimate: 85%); the middle value does not contradict the limit.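

No new step can be read from compound 3 to compound 1 or compound 2, since all three compounds stand at the same limit: the limit of > 20000 nM in this assay, at which 3 of the 3 values shown sit.

The compounds shown leave open how far each of the three lies from that limit in this assay and whether piperidin-1-yl, cyclohexylamino and cyclopentylamino on the carbonyl carbon differ at all.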